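The source may hold more compounds than are shown below. What is called first, only, known or untested is meant among the compounds shown, and "the series" means these compounds.

Measured compounds:
- compound 1, `CS(=O)(=O)Nc1ccc(C(C(=O)NCc2ccc(C(F)(F)F)nc2SC2CCCCC2)C2CCCCC2)cc1F` — an assay on CHO cells for antagonist activity at transient receptor potential cation channel subfamily V member 1 (Homo sapiens), read by FLIPR; on this read-out higher numbers stand for weaker inhibition and lower numbers for stronger inhibition: "active" (no number reported)
- compound 2, `Cc1ccccc1C(C(=O)NCc1ccc(C(F)(F)F)nc1N1CCC(C)CC1)c1ccc(NS(C)(=O)=O)c(F)c1` — this assay: 42.9 nM
- compound 3, `Cc1ccccc1C(C(=O)NCc1ccc(C(F)(F)F)nc1SC1CCCCC1)c1ccc(NS(C)(=O)=O)c(F)c1` — this assay: "active" (no number reported)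

Three compounds sharing a common core have been examined so far. In this assay, for the measured compounds named here, compound 2 gives 42.9 nM, the only single number in the set. For compound 1 the result is reported only as "active" (no number reported), without a number. For compound 3 the result is likewise given only as "active" (no number reported); no single number exists for it, and one further compound in the set is also reported without one. Compound 3 therefore stands as an active inhibitor whose strength cannot be placed on the scale relative to compound 2.

The next compound, compound 4, `CS(=O)(=O)Nc1ccc(C(Cc2ccc(F)cc2)C(=O)NCc2ccc(C(F)(F)F)nc2SC2CCCCC2)cc1F`, has not yet been measured. It differs from compound 3 in one place: 4-fluorobenzyl in place of 2-methylphenyl on a saturated chain carbon bound to an aromatic carbon and a carbonyl carbon. Going by the values given here, since compound 3 carries no number and no measured pair shows a change of this kind, the size and direction of the step cannot be anchored to the data. The change is at the saturated chain carbon bound to an aromatic carbon and a carbonyl carbon, a position where compound 1 and compound 3 show that different groups keep activity.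

Compound 4 is expected to fall near 100 nM, within a range of 20 nM to 500 nM, with the wide range reflecting that compound 3 has no number to start from.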

Compound 4, inhibition constant: "active" (no number reported)
Nothing numeric was reported for compound 4; no gap can be computed for the estimate.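

In this assay compound 4 gives "active" (no number reported) and compound 3 gives "active" (no number reported) as well, so no step can be read between compound 3 and compound 4. No evidence shown bears on this result. The compounds shown leave open how strongly compound 1, compound 3 and compound 4 inhibit compared with compound 2.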